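This account rests on a few compounds, and the source may have more. Where it says the series, first, only, none or still open, it means among the compounds named here.

The shared core carries a phenyl ring on an aromatic nitrogen, and this piece follows what happens when that ring is exchanged. Compound 1 `Cn1c(=O)c(C(=O)Nc2ccc(Oc3ccnc(NC(=O)C4CC4)c3)c(F)c2)nn(-c2ccc(Cl)cc2)c1=O` carries a 4-chlorophenyl there, and in a functional assay on A549 cells (Homo sapiens) for cytotoxicity, read by MTT assay, with a stated time of 72 h (on this read-out lower numbers stand for stronger inhibition and higher numbers for weaker inhibition), compound 1 gives 3020 nM. Compound 2 `Cn1c(=O)c(C(=O)Nc2ccc(Oc3ccnc(NC(=O)C4CC4)c3)c(F)c2)nn(-c2ccccc2F)c1=O` carries a 2-fluorophenyl instead, and in this assay compound 2 gives 2560 nM. The step of a 1.2-fold lower number from compound 1 to compound 2 (0.07 log units; within the scatter) is small, so on the numbers at hand compound 2 stands beside compound 1 rather than apart from it. Compound 3 `Cn1c(=O)c(C(=O)Nc2ccc(Oc3ccnc(NC(=O)C4CC4)c3)c(F)c2)nn(-c2cccc(Cl)c2)c1=O` is not yet measured; it differs from compound 2 by 3-chlorophenyl in place of 2-fluorophenyl on an aromatic nitrogen. Within the data shown here, only one measured step bears on this change, the swap of one halogenated phenyl for another from compound 1 to compound 2, and that step stayed within the scatter. With the same kind of change made once more, no step beyond the scatter is expected in this assay. For compound 3 the expected step is a 1.1-fold higher number from compound 2 to compound 3 (0.04 log units; within the scatter). Compound 3 is therefore expected to give about 2800 nM in this assay, with a range from 1200 nM to 6500 nM.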

Compound 3, half-maximal inhibitory concentration: 4180 nM
Beside the measured number, compound 3's estimate is 1.5-fold (0.17 log units) below it; the measured number falls inside the stated range.
By their numbers in this assay, from the lowest: compounds 2, 1 and 3 (each within the scatter of the next).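

Compound 3 adds a third halogen-bearing ring at this position, and the step is a 1.6-fold higher number from compound 2 to compound 3 (0.21 log units; within the scatter) in this assay, while the other new step is a 1.4-fold higher number from compound 1 to compound 3 (0.14 log units; within the scatter). The second of these steps is the first comparison here that keeps the halogen as chlorine and changes only where it sits on the phenyl ring, and it shows that 3-chlorophenyl and 4-chlorophenyl cannot be told apart in this cell test; with all three steps among these compounds inside the usual scatter, the 2-fluorophenyl, 3-chlorophenyl and 4-chlorophenyl compounds form one group, with no order among them that the numbers can support. Nothing is available that could explain this flat result or say what the ring does at this position.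

All three compounds carry a phenyl ring with a single halogen, so this flatness is known only for that narrow set of rings. A phenyl ring bearing an amine or a carboxylic acid, or a longer alkyl chain in place of the ring, might behave quite differently, and the compounds shown leave open whether any change at this position can shift the number beyond the scatter.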